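The source may report more compounds than this note shows. Statements on the series, on what has been measured and on what is new or still open speak of the compounds shown alone.

In a functional assay on Raji cells (Homo sapiens) for antiproliferative activity, read by MTT assay, with a stated time of 48 h (on this read-out higher numbers stand for weaker inhibition and lower numbers for stronger inhibition), compound 1 (`Cn1c(N)c(-c2nc3ccccc3[nH]2)c2nc(C#N)c(C#N)nc21`) reads > 50000 nM as a limit of the assay and not a number. Compound 2 (`CN(C)CCn1c(N)c(-c2nc3cc(Cl)ccc3[nH]2)c2nc(C#N)c(C#N)nc21`) gives 11800 nM and compound 3 (`CN(C)CCCCn1c(-c2c(N)n(C)c3nc(C#N)c(C#N)nc23)nc2ccccc21`) gives 1070 nM as the lower of the two actual numbers. Compound 4 (`CCN(CC)CCCCn1c(-c2c(N)n(C)c3nc(C#N)c(C#N)nc23)nc2ccccc21`) differs from compound 3 by diethylamino in place of dimethylamino on a saturated chain carbon, four bonds along the chain from an aromatic nitrogen as diethylamino in place of dimethylamino on a saturated chain carbon, four bonds along the chain from an aromatic nitrogen. Among the measured compounds shown here, the one measured step on this chain is large (an at least 46-fold lower number from compound 1 to compound 3 (1.66 log units; beyond the scatter)) but installs the whole 4-(dimethylamino)butyl in place of hydrogen on an aromatic nitrogen. For the measured compounds named here, no measured step varies the dimethylamino group itself. No shift beyond the scatter is therefore expected in this assay (a 1.0-fold higher number from compound 3 to compound 4 (0.01 log units; within the scatter)). For compound 4 the estimate is 1100 nM (expected range 450 nM to 2800 nM).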

Compound 4, half-maximal inhibitory concentration: 600 nM
Compound 4: middle estimate off by 1.8-fold (0.26 log units), on the high side; low and high end bracket the measured number.
By their numbers in this assay, from the lowest: compounds 4 and 3 (each within the scatter of the next); then compound 2. At a limit, above all of these: compound 1.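

Working notes: this is the first variation of the amine itself on a saturated chain carbon, four bonds along the chain from an aromatic nitrogen. In this assay diethylamino in place of dimethylamino does not separate the two amines (a 1.8-fold lower number from compound 3 to compound 4 (0.25 log units; within the scatter)), while the whole chain carrying diethylamino, set against its absence, gives a large step (an at least 83-fold lower number from compound 1 to compound 4 (1.92 log units; beyond the scatter)). Compound 1 stands at a limit, so that large step is a bound: the limit of > 50000 nM in this assay, at which 1 of the 4 values shown sits.

Open: whether a ring amine such as piperidine or morpholine fits at this chain end. As far as these compounds go, also open: whether a longer chain carrying diethylamino keeps the number of compound 4 (600 nM).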